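From methoxy to chloro on a weakly active compound

The compounds below may be only part of what the source reports. "The series", "measured", "known", "first", "only" and "open" are said of these compounds alone.

Measured so far:
compound 1 `O=C1COc2ccc(-c3cnc(Cl)c(NS(=O)(=O)c4ccc(F)cc4)c3)cc2N1c1ccc(F)cc1`: > 40000 nM (a limit)
compound 2 `O=C1COc2ccc(-c3cnc(Cl)c(NS(=O)(=O)c4ccc(F)cc4)c3)cc2N1`: > 40000 nM (a limit)
compound 3 `COc1ncc(-c2ccc3c(c2)N(C2CC2)C(=O)CO3)cc1NS(=O)(=O)c1ccc(F)cc1`: 23900 nM

In a functional assay on A-375 cells (Homo sapiens) for antiproliferative activity, read by MTT assay, with a stated time of 72 h (on this read-out higher numbers stand for weaker inhibition and lower numbers for stronger inhibition), compound 3 gives 23900 nM. For the measured compounds named here, this is the only real number of the three, as the other two values are limits and not numbers. Compound 4 `O=C1COc2ccc(-c3cnc(Cl)c(NS(=O)(=O)c4ccc(F)cc4)c3)cc2N1C1CC1` differs from compound 3 in one place: chloro in place of methoxy on an aromatic carbon.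

Compound 1 and compound 2 both carry the chloro, and both stop at the same limit: the limit of > 40000 nM in this assay, at which 2 of the 3 values shown sit. Going by the values given here, the only measured step is a step that the two limits leave unreadable from compound 1 to compound 2. Among the compounds with values here, it concerns a different group and has no readable size, so no measured step gives a size for this change.

Compound 3 at 23900 nM already lies not far from the point at which compound 1 and compound 2 stop. A modest shift toward weaker inhibition is therefore expected, and this assay may report only a limit. The expected step is a 1.6-fold higher number from compound 3 to compound 4 (0.20 log units; within the scatter). For compound 4 the estimated value is 38000 nM, expected to lie between 18000 nM and 80000 nM.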

Compound 4, half-maximal inhibitory concentration: 21800 nM
Compound 4: the middle estimate sits 1.7-fold (0.24 log units) above what was measured; measured number inside the range.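

Chloro in place of methoxy, on the carbon next to the ring nitrogen, is a 1.1-fold lower number from compound 3 to compound 4 (0.04 log units; within the scatter), so this pair gives no sign that the two groups differ here. Chloro also goes with a readable number: compound 4 carries it and gives 21800 nM. Cyclopropyl on the amide-type nitrogen gives an at least 1.8-fold lower number from compound 2 to compound 4 (0.26 log units; that floor lies within the scatter), and in place of 4-fluorophenyl it gives an at least 1.8-fold lower number from compound 1 to compound 4 (0.26 log units; that floor lies within the scatter); these are only floors, because compound 1 and compound 2 each rest on a limit rather than a number: the limit of > 40000 nM in this assay, at which 2 of the 4 values shown sit.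

From the compounds shown here alone, it remains open whether another group at this position, such as an amine or a nitrile, would move the number beyond the scatter. Going by these compounds, the true size of the steps at the amide-type nitrogen also remains open, as does the effect of a longer chain there.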